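A few compounds are considered here, and "the series" means these few. Any claim that something is new, unique, unknown or untested is made for them only; others in the source may bear on it.

Measured compounds:

Compound 1 `N#CC1=C(N)Oc2c(N)cc3nc4ccccc4nc3c2C12C(=O)N(Cc1cnnn1-c1ccc(F)cc1)c1ccccc12`: in an ADME assay on L02 cells (Homo sapiens) for antiproliferative activity, read by MTT assay, with a stated time of 48 h (on this read-out higher numbers stand for weaker inhibition and lower numbers for stronger inhibition), compound 1 gives > 50000 nM, which is a limit of the assay and not a number.
Compound 2 `N#CC1=C(N)Oc2c(N)cc3nc4ccccc4nc3c2C12C(=O)N(Cc1cnnn1-c1ccc(Cl)cc1)c1ccccc12`: in this assay compound 2 gives > 50000 nM, again a limit of the assay.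
Compound 3 `N#CC1=C(N)Oc2c(N)cc3nc4ccccc4nc3c2C12C(=O)N(Cc1cnnn1-c1cccc(C(F)(F)F)c1)c1ccccc12`: in this assay compound 3 gives 38100 nM.

For the measured compounds named here, compound 3 holds the only real number among the three; the other two values sit at the limit of > 50000 nM in this assay, at which 2 of the 3 values shown sit. The steps to it are therefore only floors: an at least 1.3-fold lower number from compound 1 to compound 3 (0.11 log units; that floor lies within the scatter) and an at least 1.3-fold lower number from compound 2 to compound 3 (0.11 log units; that floor lies within the scatter), each a floor that stays within the scatter, so the three compounds cannot be ordered with confidence.

Compound 4 `COc1ccc(-n2nncc2CN2C(=O)C3(C(C#N)=C(N)Oc4c(N)cc5nc6ccccc6nc5c43)c3ccccc32)cc1` differs from compound 3 in one place: 4-methoxyphenyl in place of 3-(trifluoromethyl)phenyl on an aromatic nitrogen. The measured steps bear on it only loosely, since they change the same phenyl substituent and were all small or unreadable. The expectation is therefore a step of a 1.2-fold higher number from compound 3 to compound 4 (0.07 log units; within the scatter), that is, no change beyond the scatter in this assay. Compound 4 is estimated at 45000 nM, with a range from 25000 nM to 90000 nM, and a fair chance that the assay again reports only a limit.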

Compound 4, half-maximal inhibitory concentration: > 50000 nM
Compound 4: a limit, no number (the forecaster's own chance of this, stated with the estimate: 55%); middle value at least 1.1-fold (0.04 log units) away from the limit.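

Replacing 3-(trifluoromethyl)phenyl with 4-methoxyphenyl on the aromatic nitrogen gives an at least 1.3-fold higher number from compound 3 to compound 4 (0.11 log units; that floor lies within the scatter), so a real shift is neither shown nor ruled out. The steps from compound 1 and from compound 2 to compound 4 cannot be read, because each joins two limits: the limit of > 50000 nM in this assay, at which 3 of the 4 values shown sit. In this assay, compound 4 with its 4-methoxyphenyl now joins compound 1 with its 4-fluorophenyl and compound 2 with its 4-chlorophenyl in reporting only a limit, while compound 3 alone gives a number.

The compounds shown do not tell whether that number goes with the trifluoromethyl group itself or with where it sits on the phenyl ring. From the compounds shown here alone, how a 3-methoxyphenyl, or a phenyl ring carrying an amine or a carboxylic acid, would read in this assay also remains open.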